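A few compounds are considered here, and "the series" means these few. Any claim that something is new, unique, unknown or untested is made for them only; others in the source may bear on it.

Measured so far:
- compound 1 `Cn1nncc1-c1cnn([C@H](CC2CC2)c2ccc(-c3c(-n4cnnn4)ccc(Cl)c3F)c[n+]2[O-])c1` gives > 3 h as a limit
- compound 2 `Cn1nncc1-c1cnn([C@H](CCOC(F)F)c2ccc(-c3c(-n4cnnn4)ccc(Cl)c3F)c[n+]2[O-])c1` gives > 3.08 h as a limit

In an ADME assay on microsomes from liver (Rattus norvegicus) for metabolic stability (a higher number here means that the compound lasts longer, a lower number that the compound disappears faster), compound 2 stands at > 3.08 h and this is a limit, not a number. Compound 1 also gives only a limit, > 3 h in the same read-out. The next compound is compound 3 `Cn1nncc1-c1cnn([C@H](CCOC(F)F)c2ccc(-c3c(-n4cc(C(F)(F)F)nn4)ccc(Cl)c3F)c[n+]2[O-])c1` and its change from compound 2 is 4-(trifluoromethyl)-1H-1,2,3-triazol-1-yl in place of 1H-tetrazol-1-yl on an aromatic carbon on the ring of carbon only, with 4-(trifluoromethyl)-1H-1,2,3-triazol-1-yl in place of 1H-tetrazol-1-yl. Within the data shown here, the single measured step is a step that the two limits leave unreadable from compound 1 to compound 2 and it lies on the saturated chain, elsewhere in the molecule. Among the measured compounds shown here, no measured compound carries a change at the new place, so neither size nor direction can be taken from the data. The expected step is an at least 1.0-fold lower number from compound 2 to compound 3 (0.01 log units; that floor lies within the scatter) with wide margins, and no step beyond the scatter is firmly expected. For compound 3 the estimate is 3 h with an expected range from 1.3 h to 6 h in this assay terms.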

Compound 3, half-life: 2.42 h
Estimate against measurement, compound 3: 1.2-fold (0.09 log units) above; low and high end bracket the measured number.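

In this assay, compound 3 is the only compound shown with a number rather than a limit, and it gives the first reading of a change at this place, on the aromatic carbon ortho to a large group: 2.42 h. Replacing 1H-tetrazol-1-yl with 4-(trifluoromethyl)-1H-1,2,3-triazol-1-yl gives an at least 1.2-fold lower number from compound 2 to compound 3 (0.10 log units; that floor lies within the scatter), so the printed floor shows no step beyond the scatter, though the real step may be larger. Compound 2 stands only at a limit, which leaves the true size of the step open: the limit of > 3.08 h in this assay, at which 1 of the 3 values shown sits.

The step on the saturated chain cannot be read, so the two places cannot be compared. Also open, from the compounds shown here alone, is how a nitrile or an amine at the aromatic carbon would read in this assay.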